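A chlorine added on the acetamide of compound 3

The compounds below may be only part of what the source reports. "The series", "measured", "known", "first", "only" and "open" are said of these compounds alone.

Of the compounds shown here, three have been tested in a functional assay on M21 cells (Homo sapiens) for antiproliferative activity, read by sulforhodamine B assay, with a stated time of 48 h; on this read-out higher numbers stand for weaker inhibition and lower numbers for stronger inhibition. Compound 1 `CC(C)C(=O)Nc1cccc(S(=O)(=O)Oc2ccccc2C(C)C)c1` gives 17000 nM, compound 2 `CC(=O)Nc1ccc(S(=O)(=O)Oc2ccccc2C(C)C)cc1` gives 21000 nM, and compound 3 `CC(=O)Nc1ccc(S(=O)(=O)Oc2ccccc2I)cc1` gives 27000 nM. Compound 3 stands at the high end of these three numbers, yet its gaps to compound 2 and to compound 1 are both within the scatter, so none of the three can be called weaker than another. Among the compounds with values here, the only single-point step, a 1.3-fold higher number from compound 2 to compound 3 (0.11 log units; within the scatter), also stayed within the scatter. Compound 4 `O=C(CCl)Nc1ccc(S(=O)(=O)Oc2ccccc2I)cc1` differs from compound 3 by chloro in place of hydrogen on a saturated chain carbon bound to a carbonyl carbon. Within the data shown here, no measured step touches this part of the molecule, so nothing measured bears directly on it. For compound 4 a step of a 2.3-fold lower number from compound 3 to compound 4 (0.35 log units; beyond the scatter) in this assay is expected. Compound 4 is estimated at 12000 nM, between 3000 nM and 40000 nM.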

Compound 4, half-maximal inhibitory concentration: 3900 nM
Beside the measured number, compound 4's estimate is 3.1-fold (0.49 log units) above it; the range from low to high includes it.
By their numbers in this assay, from the lowest: compound 4; then compounds 1, 2 and 3 (each within the scatter of the next).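

In this assay chloro in place of hydrogen on a saturated chain carbon bound to a carbonyl carbon gives a 6.9-fold lower number from compound 3 to compound 4 (0.84 log units; beyond the scatter) and this is the first step among the compounds shown to lie beyond the scatter. The acetamido group is therefore a place where a single added chlorine atom moves the number, which the step from isopropyl to iodo did not do. No measurement shown explains this shift.

As far as these compounds go, whether chlorine itself matters stays open, since bromine, a hydroxyl group or an amine on this carbon could be compared with it. From the compounds shown here alone, a longer chain carrying the chlorine is equally open, as is the same chloro change on compound 2.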